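The source may hold more compounds than are shown below. What is called first, only, known or untested is meant among the compounds shown, and "the series" means these compounds.

- Compound 1 `Cn1cc(-c2ccc(=O)n(CCOc3ccnc4cc(OCCCCCCC(=O)NO)ccc34)n2)cn1`: 210 nM
- Compound 2 `Cn1cc(-c2ccc(=O)n(CCOc3ccnc4cc(OCc5ccc(C(=O)Nc6ccccc6N)cc5)ccc34)n2)cn1`: 42 nM
- Compound 3 `Cn1cc(-c2ccc(=O)n(CCOc3ccnc4cc(OCc5ccc(/C=C/C(=O)Nc6ccccc6N)cc5)ccc34)n2)cn1`: 490 nM

All three compounds were tested in a functional assay on EBC-1 cells (Homo sapiens) for antiproliferative activity, read by sulforhodamine B assay, with a stated time of 72 h; on this read-out lower numbers stand for stronger inhibition and higher numbers for weaker inhibition. Among them, compound 3 has the highest number, at 490 nM, and so shows the weakest inhibition. Compound 4 `Cn1cc(-c2ccc(=O)n(CCOc3ccnc4cc(OCc5ccc(CCC(=O)Nc6ccccc6N)cc5)ccc34)n2)cn1` differs from it in one place: 2-((2-aminophenyl)carbamoyl)ethyl in place of 2-((2-aminophenyl)carbamoyl)ethenyl on an aromatic carbon. In words, 2-((2-aminophenyl)carbamoyl)ethyl takes the place of 2-((2-aminophenyl)carbamoyl)ethenyl on an aromatic carbon, para to a large group.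

For the measured compounds named here, only one measured step bears on this place, a large one: a 12-fold higher number from compound 2 to compound 3 (1.07 log units; beyond the scatter). That step swapped (2-aminophenyl)carbamoyl for the ethenyl group. Going by the values given here, the new change is a smaller edit, turning ethenyl into ethyl, and no measured pair shows such a change directly. A step beyond the scatter is therefore not expected, though a slight lean towards a lower number seems reasonable. The expected change is a 1.4-fold lower number from compound 3 to compound 4 (0.15 log units; within the scatter). For compound 4, the estimated value is 350 nM, with an expected range of 120 nM to 1000 nM.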

Compound 4, half-maximal inhibitory concentration: 210 nM
Compound 4: the middle estimate sits 1.7-fold (0.22 log units) above what was measured, within the range that was stated.
By their numbers in this assay, from the lowest: compound 2; then compounds 1 and 4 (each within the scatter of the next); then compound 3.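

In this assay, removing only the double bond of the linker, while the count of heavy atoms stays the same, gives a 2.3-fold lower number from compound 3 to compound 4 (0.37 log units; beyond the scatter) and shows that the double bond itself matters at this position, not just the size of the group. The saturated chain does not close the whole gap to the directly attached (2-aminophenyl)carbamoyl group, as there is still a 5.0-fold higher number from compound 2 to compound 4 (0.70 log units; beyond the scatter) and so the three groups at this position now fall in a clear order: directly attached lowest, ethyl next, ethenyl highest. No supporting measurement speaks to the reason for these differences.

As far as these compounds go, it remains open how a longer chain would behave at this position. An amine or an ether oxygen within the linker is equally untested by the compounds shown.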